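Fluorophenyl swap from compound 3 to compound 4

The source may hold more compounds than are shown below. What is called first, only, known or untested is meant among the compounds shown, and "the series" means these compounds.

In an ADME assay on MT4 cells (Homo sapiens) for cytotoxicity, read by MTT assay (a higher number here means that more compound is tolerated, a lower number that less compound is tolerated), compound 1 (`Cc1ccc(CNC(=O)c2[nH]c3ccc(Cl)cc3c2S(=O)(=O)c2cc(C)cc(C)c2)cc1`) gives 21200 nM. Compound 2 (`Cc1cc(C)cc(S(=O)(=O)c2c(C(=O)NCc3ccc(Cl)cc3)[nH]c3ccc(Cl)cc23)c1`) gives > 51200 nM, which is a limit of the assay. Compound 3 (`Cc1cc(C)cc(S(=O)(=O)c2c(C(=O)NCc3cccc(F)c3)[nH]c3ccc(Cl)cc23)c1`) stands at > 53000 nM, also only a limit and not a number.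

Compound 4 (`Cc1cc(C)cc(S(=O)(=O)c2c(C(=O)NCc3ccc(F)cc3)[nH]c3ccc(Cl)cc23)c1`) carries 4-fluorophenyl in place of 3-fluorophenyl on a saturated chain carbon bound to an amide-type nitrogen.

The nearest measured comparison is a step that the two limits leave unreadable from compound 2 to compound 3. The two other measured steps are an at least 2.4-fold higher number from compound 1 to compound 2 (0.38 log units; beyond the scatter) and an at least 2.5-fold higher number from compound 1 to compound 3 (0.39 log units; beyond the scatter), both beyond the scatter. Compound 1 with its 4-methylphenyl is thus the low end of the series, while the 4-chlorophenyl of compound 2 keeps the same ring position, so that position alone does not mark a low value.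

No step beyond the scatter is therefore expected in this assay, and a limit is the likely report. The estimated change is an at least 1.0-fold lower number from compound 3 to compound 4 (0.02 log units; that floor lies within the scatter). For compound 4 the estimate is 50000 nM, with an expected range of 22000 nM to 62000 nM.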

Compound 4, half-maximal cytotoxic concentration: > 53000 nM
Compound 4: only a limit was reported (the forecaster's own chance of this, stated with the estimate: 65%); at least 1.0-fold (0.02 log units) between middle value and limit.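

In this assay compound 4 gives > 53000 nM, which is a limit of the assay and not a number. Moving the fluoro from 3-fluorophenyl to 4-fluorophenyl therefore leaves the series at a limit, and neither the step from compound 3 to compound 4 nor the step from compound 2 to compound 4 can be read: the limit of > 53000 nM in this assay, at which 2 of the 4 values shown sit. Exchanging the methyl for fluoro gives an at least 2.5-fold higher number from compound 1 to compound 4 (0.39 log units; beyond the scatter), so 4-fluorophenyl joins the 4-chlorophenyl of compound 2 in standing clear of 4-methylphenyl.

From the compounds shown here alone, how 3-fluorophenyl, 4-fluorophenyl and 4-chlorophenyl rank in this assay stays open, as none of them has a number there. Also open, going by these compounds, is whether the lower value of compound 1 is particular to methyl or extends to an ethyl, an amine or a carboxylic acid on that phenyl ring.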